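This account rests on a few compounds, and the source may have more. Where it says the series, first, only, none or still open, it means among the compounds named here.

Measured in a functional assay on NB1 cells (Homo sapiens) for cytotoxicity, read by MTT assay, with a stated time of 3 days; a lower number here means a stronger inhibitor, a higher number a weaker inhibitor:
- Compound 1 `CNc1nc(SCc2nc3ccccc3[nH]2)nc(-c2ccccc2)c1C#N` gives 4.46 nM
- Compound 2 `CCNc1nc(SCc2nc3ccccc3[nH]2)nc(-c2ccccc2)c1C#N` gives 2.63 nM
- Compound 3 `N#Cc1c(NNC(N)=S)nc(SCc2nc3ccccc3[nH]2)nc1-c1ccccc1` gives 5.81 nM

Compound 3 cannot be told apart from its nearest neighbour (a 1.3-fold higher number from compound 1 to compound 3 (0.11 log units; within the scatter)), and only its gap to the other compound clears the scatter (a 2.2-fold higher number from compound 2 to compound 3 (0.34 log units; beyond the scatter)). Compound 4 `N#Cc1c(-c2ccccc2)nc(SCc2nc3ccccc3[nH]2)nc1N1CCNCC1` is still unmeasured. Among the compounds with values here, its change from compound 3 is a group of 6 heavy atoms (4 carbon, 2 nitrogen; one six-membered non-aromatic ring with 2 hetero atoms) in place of a group of 5 heavy atoms (1 carbon, 3 nitrogen, 1 sulfur; no ring), on an aromatic carbon and brings in a piperazin-1-yl ring, which no measured compound carries at this place. The nearest evidence is therefore indirect: the other changes here stayed small (a 1.7-fold lower number from compound 1 to compound 2 (0.23 log units; within the scatter)) and modest (also a 2.2-fold higher number from compound 2 to compound 3 (0.34 log units; beyond the scatter)). No step beyond the scatter is expected in this assay, and no direction is favoured. The expected step is small (a 1.3-fold lower number from compound 3 to compound 4 (0.11 log units; within the scatter)). For compound 4 the estimated value is 4.5 nM (expected range 1.5 nM to 14 nM).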

Compound 4, half-maximal inhibitory concentration: 6.75 nM
Compound 4: middle estimate off by 1.5-fold (0.18 log units), on the low side; the range from low to high includes it.
By their numbers in this assay, from the lowest: compounds 2, 1, 3 and 4 (each within the scatter of the next, the first and the last beyond it).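

In this assay, this aromatic carbon accepts a saturated ring as well as open groups: piperazin-1-yl cannot be told apart from the open group it replaces (a 1.2-fold higher number from compound 3 to compound 4 (0.07 log units; within the scatter)) or from methylamino (a 1.5-fold higher number from compound 1 to compound 4 (0.18 log units; within the scatter)). Only against ethylamino does the gap clear the scatter, and then only modestly (a 2.6-fold higher number from compound 2 to compound 4 (0.41 log units; beyond the scatter)). Across these replacements, the change in group size and shape moved the number little.

No measurement shown here accounts for these values. On these data alone, whether morpholine, piperidine or 4-methylpiperazin-1-yl at this place would behave like piperazin-1-yl remains open.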